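Benzylamino in place of 2-methoxyethoxy at the carbonyl carbon

This account rests on a few compounds, and the source may have more. Where it says the series, first, only, none or still open, it means among the compounds named here.

Compound 1 `CCCCCCCC(=O)Nc1nc2ccc(NC(=O)c3c(Cl)cccc3Cl)cc2s1`: in a functional assay on WI-38 VA13 cells (Homo sapiens) for cytotoxicity (a lower number here means that less compound is needed, a higher number that more compound is needed for the effect), compound 1 gives 0.18 ug/mL.
Compound 2 `O=C(O)CCC(=O)Nc1nc2ccc(NC(=O)c3c(Cl)cccc3Cl)cc2s1`: in this assay compound 2 reaches only a limit, > 6.6 ug/mL (the limit of > 6.6 ug/mL in this assay, at which 1 of the 3 values shown sits).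
Compound 3 `COCCOC(=O)Nc1nc2ccc(NC(=O)c3c(Cl)cccc3Cl)cc2s1`: in this assay compound 3 gives 0.011 ug/mL.

Among the two numbers, compound 3 stands lowest; its nearest neighbour is compound 1, separated by a 16-fold lower number from compound 1 to compound 3 (1.21 log units; beyond the scatter). Compound 4 `O=C(NCc1ccccc1)Nc1nc2ccc(NC(=O)c3c(Cl)cccc3Cl)cc2s1` differs from compound 3 by benzylamino in place of 2-methoxyethoxy on a carbonyl carbon. Among the measured compounds shown here, no measured step makes this exact exchange, but the two steps at the carbonyl carbon, a 16-fold lower number from compound 1 to compound 3 (1.21 log units; beyond the scatter) and an at least 600-fold lower number from compound 2 to compound 3 (2.77 log units; beyond the scatter), were both large, so this position moves the number strongly. A large step upward is therefore expected, a 9.1-fold higher number from compound 3 to compound 4 (0.96 log units; beyond the scatter). Compound 4 is estimated at 0.1 ug/mL, with a range from 0.02 ug/mL to 0.6 ug/mL.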

Compound 4, half-maximal effective concentration: 0.15 ug/mL
Estimate against measurement, compound 4: 1.5-fold (0.18 log units) below; measured number inside the range.
By their numbers in this assay, from the lowest: compound 3; then compounds 4 and 1 (each within the scatter of the next). At a limit, above all of these: compound 2.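

Exchanging 2-methoxyethoxy for benzylamino on this carbonyl carbon gives up the low reading of compound 3 in this assay, with a 14-fold higher number from compound 3 to compound 4 (1.13 log units; beyond the scatter). Benzylamino, with its aromatic ring and hydrogen-bond donor, reads level with heptyl, a 1.2-fold lower number from compound 1 to compound 4 (0.08 log units; within the scatter), so among these groups only 2-methoxyethoxy stands apart. Compound 2 reaches only a limit, which makes the step to benzylamino a bound, an at least 44-fold lower number from compound 2 to compound 4 (1.64 log units; beyond the scatter), set by this value: the limit of > 6.6 ug/mL in this assay, at which 1 of the 4 values shown sits.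

The compounds shown leave open whether the linking nitrogen or the side group sets the number. Benzyloxy, which keeps the benzyl group on an oxygen, and 2-methoxyethylamino, which keeps the ether chain on a nitrogen, would separate the two.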